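The compounds below may be only part of what the source reports. "The series", "measured", "known", "first", "only" and "open" are said of these compounds alone.

Compound 1 `COCCOc1ccc2nccc(SC3(C(=O)O)CCC3)c2c1` was tested in an assay on HEK293 cells for inhibition of solute carrier family 22 member 12 (Homo sapiens), read by scintillation counting, with a stated time of 12 min (a higher number here means a weaker inhibitor, a lower number a stronger inhibitor), where compound 1 gives 207 nM. Two related compounds with the same core were measured alongside it. Compound 2 `N#Cc1ccc(SC2(C(=O)O)CCC2)c2ccccc12` gives 926 nM, and compound 3 `O=C(O)C1(Sc2ccnc3ccc(-c4ccccc4C(F)(F)F)cc23)CCC1` gives 115 nM. Among these three numbers compound 1 stands second highest: its number lies close to that of compound 3, within the usual scatter of repeated measurements, while the gap to compound 2 is clearly beyond the scatter, with compound 2 the higher of the two.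

Compound 4 `O=C(O)C1(Sc2ccnc3ccc(-c4ccc(F)cc4)cc23)CCC1` has not yet been measured. It arises from compound 1 by a single change: 4-fluorophenyl in place of 2-methoxyethoxy on an aromatic carbon. Within the data shown here, no measured pair of compounds in this set differs in only that one place, so the size of the step has to be judged from the set as a whole. Compound 3, in which a different substituted phenyl ring takes the place of the chain, gives 115 nM, a number within the scatter of compound 1. On that basis the step of a 1.6-fold lower number from compound 1 to compound 4 (0.20 log units; within the scatter) is expected to be small, toward a slightly lower number or none beyond the scatter. Compound 4 is estimated at 130 nM, with a likely range from 50 nM to 350 nM.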

Compound 4, half-maximal inhibitory concentration: 159 nM
Estimate against measurement, compound 4: 1.2-fold (0.09 log units) below, and the stated range covers the measured number.
By their numbers in this assay, from the lowest: compounds 3, 4 and 1 (each within the scatter of the next); then compound 2.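

In this assay, replacing 2-methoxyethoxy with 4-fluorophenyl on this aromatic carbon gives the first step measured directly at this position (a 1.3-fold lower number from compound 1 to compound 4 (0.11 log units; within the scatter)), and that step stays within the scatter. For this one pair, a chain with no ring and hydrogen-bond acceptors and a carbon-only aromatic ring with a fluorine and no acceptors therefore give numbers that cannot be told apart, so the acceptors of the chain are not needed to keep the number in this range when 4-fluorophenyl takes its place. No measurement here explains why two such different groups give numbers this close.

The compounds shown cannot say whether this tolerance extends to other kinds of group on this carbon, such as an amine, a carboxylic acid or a longer chain, since each could move the number in either direction. They also leave open what the fluorine contributes, which a plain phenyl ring on the same carbon of the core would test directly against compound 4.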